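The source may hold more compounds than are shown below. What is called first, only, known or untested is meant among the compounds shown, and "the series" means these compounds.

Among the compounds with values here, compound 2 `Cn1cnc2c(N3CCCCC3)nc(-c3cccc(Cl)c3)nc21` carries the only plain number in an assay on cells for displacement of a labelled ligand from adenosine receptor A2b (Homo sapiens), read by scintillation counting and radioligand binding, with a stated time of 30 min, tested at 10 uM (a higher number here means more inhibition at the concentration tested (going by the name of the read-out), a lower number less inhibition), where compound 2 gives 24.2%. Compound 1 `Clc1cccc(-c2nc(N3CCCCC3)c3nc[nH]c3n2)c1` is the other compound measured; in this assay compound 1 gives > 80%, which is a limit of the assay rather than a number (the limit of > 80% in this assay, at which 1 of the 2 values shown sits). Within the data shown here, the single measured step, methyl in place of hydrogen on an aromatic nitrogen, was a number at least 55.8 percentage points lower from compound 1 to compound 2 (beyond the scatter). Compound 3 `Cn1cnc2c(N3CCCCC3)nc(-c3cccc(O)c3)nc21` differs from compound 2 by hydroxy in place of chloro on an aromatic carbon. Among the measured compounds shown here, no measured step bears on a change of this kind, so no shift beyond the scatter is expected, an estimated a number 3.8 percentage points higher from compound 2 to compound 3 (within the scatter). Compound 3 is therefore expected to give 28%, between 5% and 60%.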

Compound 3, a percentage reported as inhibition, at one concentration (the size of the read-out at that concentration, not a potency): 29.3%
For compound 3 the middle estimate is 1.3 percentage points below the measured one, within the range that was stated.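

In this assay, going from 3-chlorophenyl to 3-hydroxyphenyl gave a number 5.1 percentage points higher from compound 2 to compound 3 (within the scatter). With methyl on the aromatic nitrogen, chloro and hydroxy on this aromatic carbon therefore cannot be told apart, which the step on the nitrogen alone could not show. Nothing shown here accounts for this result.

On these data alone, it remains open whether an amine or a carboxylic acid on this carbon would shift the read-out. As far as these compounds go, it also remains open whether hydroxy would read the same with hydrogen in place of methyl on the aromatic nitrogen.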